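Benzyl amides on the hydroxy-indazole core: compound 4

The compounds below may be only part of what the source reports. "The series", "measured", "known", "first", "only" and "open" are said of these compounds alone.

Measured so far in a functional assay on A2780 cells (Homo sapiens) for antiproliferative activity, read by resazurin assay, with a stated time of 72 h; on this read-out lower numbers stand for stronger inhibition and higher numbers for weaker inhibition:
compound 1 `CN(C(=O)c1cc2c(Cc3ccccc3)n[nH]c2cc1O)c1ccco1` gives 2500 nM
compound 2 `CN(Cc1ccccc1Cl)C(=O)c1cc2c(Cc3ccccc3)n[nH]c2cc1O` gives 1100 nM
compound 3 `CN(Cc1ccc(Br)cc1)C(=O)c1cc2c(Cc3ccccc3)n[nH]c2cc1O` gives 2800 nM

Compound 1 stands second highest of the three numbers in this assay. Its nearest neighbour is compound 3, a step of a 1.1-fold higher number from compound 1 to compound 3 (0.05 log units; within the scatter), within the scatter. Its furthest is compound 2, a step of a 2.3-fold lower number from compound 1 to compound 2 (0.36 log units; beyond the scatter), a modest drop beyond the scatter. Between the two benzyl analogues the step is a 2.5-fold higher number from compound 2 to compound 3 (0.41 log units; beyond the scatter), so the 2-chlorobenzyl and 4-bromobenzyl amides do not read alike.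

Compound 4 `CCOc1ccc(CN(C)C(=O)c2cc3c(Cc4ccccc4)n[nH]c3cc2O)cc1` is not yet measured. Relative to compound 1 the change is 4-ethoxybenzyl in place of furan-2-yl on an amide-type nitrogen.

Within the data shown here, the steps that bear on this are the two replacements of furan-2-yl by a benzyl group: from compound 1 to compound 2 a 2.3-fold lower number from compound 1 to compound 2 (0.36 log units; beyond the scatter), and from compound 1 to compound 3 a 1.1-fold higher number from compound 1 to compound 3 (0.05 log units; within the scatter). Of these, 4-bromobenzyl in compound 3 is the closer comparison to 4-ethoxybenzyl, and that step stayed within the scatter. The expectation for compound 4 is therefore no step beyond the scatter, a 1.0-fold higher number from compound 1 to compound 4 (0.02 log units; within the scatter), with the result of compound 2 showing that a modest drop cannot be excluded. Compound 4 is estimated at 2600 nM, range 1200 nM to 5500 nM.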

Compound 4, half-maximal inhibitory concentration: 3200 nM
Estimate against measurement, compound 4: 1.2-fold (0.09 log units) below; low and high end bracket the measured number.
By their numbers in this assay, from the lowest: compound 2; then compounds 1, 3 and 4 (each within the scatter of the next).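

On the amide-type nitrogen, 4-ethoxybenzyl (10 heavy atoms) replaces furan-2-yl (5 heavy atoms), yet in this assay the step is a 1.3-fold higher number from compound 1 to compound 4 (0.11 log units; within the scatter), so this larger group with a longer substituent leaves the number within the scatter. Among these compounds, the exchange of bromo for ethoxy on an aromatic carbon, a comparison the earlier compounds did not offer, gives a 1.1-fold higher number from compound 3 to compound 4 (0.06 log units; within the scatter), while the change from 2-chlorophenyl to 4-ethoxyphenyl gives a 2.9-fold higher number from compound 2 to compound 4 (0.46 log units; beyond the scatter), so the 2-chlorobenzyl amide is now set apart from three other amides rather than two. No measurement among the data shown accounts for any of these steps.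

The compounds shown do not separate the chloro group itself from its place on the ring, since the 2-chlorobenzyl amide differs from the other two benzyl amides in both. Also open is how an amine or a carboxylic acid carried on the benzyl ring would read in this assay, as every benzyl substituent shown is a halogen or an ether.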